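This account rests on a few compounds, and the source may have more. Where it says the series, first, only, none or still open, it means among the compounds named here.

Working notes on the series. In a functional assay on A549 cells (Homo sapiens) for cytotoxicity, read by MTT assay, with a stated time of 72 h (on this read-out higher numbers stand for weaker inhibition and lower numbers for stronger inhibition), compound 1 `Cc1cc(=O)n(-c2cccc(F)c2)nc1C(=O)Nc1ccc(Oc2ncnc3[nH]ccc23)cc1` gives 34800 nM, and compound 2 `Cc1cc(=O)n(-c2cccc(F)c2)nc1C(=O)Nc1ccc(Oc2ncnc3[nH]ccc23)c(F)c1` gives 31500 nM. Within the data shown here, the single measured step, a 1.1-fold lower number from compound 1 to compound 2 (0.04 log units; within the scatter), puts the two within the scatter of each other, so no separation between compound 1 and compound 2 can be read from these numbers. Compound 3 `Cc1cc(=O)n(-c2cccc(C(F)(F)F)c2)nc1C(=O)Nc1ccc(Oc2ncnc3[nH]ccc23)c(F)c1` differs from compound 2 by trifluoromethyl in place of fluoro on an aromatic carbon, the group sitting on an aromatic carbon of a six-membered aromatic ring of carbon only, meta to a large group. Among the measured compounds shown here, no measured step touches this ring or this exchange; the one step known concerns a different ring and a different group, and it was itself within the scatter. Nothing in the data therefore supports a step of any direction beyond the scatter, and the expected step of a 1.1-fold lower number from compound 2 to compound 3 (0.05 log units; within the scatter) is set near zero with a wide range. Compound 3 is estimated at 28000 nM in this assay, with a range from 8000 nM to 90000 nM.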

Compound 3, half-maximal inhibitory concentration: 35100 nM
Beside the measured number, compound 3's estimate is 1.3-fold (0.10 log units) below it; low and high end bracket the measured number.
By their numbers in this assay, from the lowest: compounds 2, 1 and 3 (each within the scatter of the next).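

Among these compounds, the exchange of fluoro for trifluoromethyl on this aromatic carbon gives a 1.1-fold higher number from compound 2 to compound 3 (0.05 log units; within the scatter) in this assay, the first measured step at this position. Going from 3-fluorophenyl to 3-(trifluoromethyl)phenyl, with 4 heavy atoms in the entering group against 1 in the group that leaves, therefore yields no separation between compound 2 and compound 3 on this read-out. No available measurement bears on what lies behind this result.

Going by these compounds, it remains open whether a group of another kind on this aromatic carbon, such as an amine, a carboxylic acid or a nitrile, would give a step beyond the scatter. Also open, on these data alone, is whether the same exchange would give a comparable step on the core of compound 1, which lacks the fluoro of compound 2.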